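Sulfur-linked aryl exchange on the shared core

The source may report more compounds than this note shows. Statements on the series, on what has been measured and on what is new or still open speak of the compounds shown alone.

In a functional assay on U-937 cells (Homo sapiens) for antagonist activity, read by calcium flux; a lower number here means a stronger inhibitor, a higher number a weaker inhibitor:
- compound 1 `COc1ccc(CCCCCCCCOc2ccc(C[S+]([O-])c3ccccc3)nc2/C=C/C(=O)O)cc1`: 280 nM
- compound 2 `COc1ccc(CCCCCCCCOc2ccc(C[S+]([O-])c3cccc(NS(=O)(=O)c4ccccc4)c3)nc2/C=C/C(=O)O)cc1`: 150 nM
- compound 3 `COc1ccc(CCCCCCOc2ccc(CC(O)c3cccc(C(=O)O)c3)nc2/C=C/C(=O)O)cc1`: 4000 nM

Compound 1 stands second highest of these three numbers. Among the measured compounds shown here, it lies within the scatter of compound 2 and well under compound 3, which differs from it in more than one place and offers no usable step.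

The next compound to be tested is compound 4 `COc1ccc(CCCCCCCCOc2ccc(CSc3cccc(N)c3)nc2/C=C/C(=O)O)cc1`. Its change from compound 1 is a group of 8 heavy atoms (6 carbon, 1 nitrogen, 1 sulfur; one six-membered aromatic ring of carbon only) in place of a group of 8 heavy atoms (6 carbon, 1 oxygen, 1 sulfur; one six-membered aromatic ring of carbon only), on a saturated chain carbon bound to an aromatic carbon: (3-aminophenyl)sulfanyl enters on a saturated chain carbon bound to an aromatic carbon.

For the measured compounds named here, only one measured step bears on this change. Placing (phenylsulfonyl)amino in place of hydrogen on an aromatic carbon gave a 1.9-fold lower number from compound 1 to compound 2 (0.27 log units; within the scatter). That step is small, although the added group is sizeable, so substitution on this aromatic ring has so far shown no effect beyond the scatter. Going by the values given here, no measured pair isolates either part of the exchange in compound 4, so the estimate stays loose.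

No step beyond the scatter is expected in this assay, and the estimated step is a 1.1-fold lower number from compound 1 to compound 4 (0.05 log units; within the scatter). Compound 4 is expected at 250 nM, with an estimated range of 90 nM to 700 nM.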

Compound 4, half-maximal inhibitory concentration: 54 nM
For compound 4 the middle estimate is 4.6-fold (0.67 log units) above the measured one, and the stated range ends above it.
By their numbers in this assay, from the lowest: compound 4; then compounds 2 and 1 (each within the scatter of the next); then compound 3.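

Notes on the sulfur-linked aryl exchange: in this assay the exchange at this saturated chain carbon bound to an aromatic carbon gives a 5.2-fold lower number from compound 1 to compound 4 (0.71 log units; beyond the scatter) and is the first single-place change in the series to pass beyond the scatter, whereas the earlier change on the aromatic ring, a 1.9-fold lower number from compound 1 to compound 2 (0.27 log units; within the scatter), stayed within it. The position therefore responds to a change in the sulfur-linked group, but this step swaps a whole group: an oxygen leaves, a nitrogen enters, and the entering (3-aminophenyl)sulfanyl carries 1 hydrogen-bond donor and 2 hydrogen-bond acceptors against 0 and 1 for the group it replaces, so the step cannot be divided among these differences. No measurement accompanies this result that would account for it.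

The compounds shown leave open how much of the step belongs to the oxygen and how much to the amine, a split that a plain phenylsulfanyl group or a (3-aminophenyl)sulfinyl group on the shared core would settle. Also open, from the compounds shown here alone, is whether the amine itself matters or whether an acetylamino group, a hydroxyl or a methoxy on the same ring would serve equally.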